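Amine chain isomers on the shared core

A few compounds are considered here, and "the series" means these few. Any claim that something is new, unique, unknown or untested is made for them only; others in the source may bear on it.

In an ADME assay on microsomes from liver (Homo sapiens) for metabolic stability, read by LC-MS, tested at 1 uM (on this read-out higher numbers stand for fast clearance and lower numbers for slow clearance), compound 1 (`c1cc([C@H]2CC[C@]3(CC2)OOC2(O3)C3CC4CC(C3)CC2C4)ccc1OCCOC1CCNCC1`) gives < 7 mL.min-1.g-1, which is a limit. Compound 2 (`CC(C)(CN)Oc1ccc([C@H]2CC[C@]3(CC2)OOC2(O3)C3CC4CC(C3)CC2C4)cc1`) gives < 7 mL.min-1.g-1, also a limit and no number. Compound 3 (`NCCCCOc1ccc([C@H]2CC[C@]3(CC2)OOC2(O3)C3CC4CC(C3)CC2C4)cc1`) differs from compound 2 as follows: 4-aminobutyl in place of 1-(aminomethyl)-1-methylethyl on an oxygen on an aromatic ring. Among the measured compounds shown here, the one measured step that bears on this change is a step that the two limits leave unreadable from compound 1 to compound 2, so it offers no size to carry over. In this assay the expected change is a step that the limit leaves unreadable from compound 2 to compound 3, with none beyond the scatter anticipated. The estimate for compound 3 is 6 mL.min-1.g-1, with an expected range of 3 mL.min-1.g-1 to 15 mL.min-1.g-1.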

Compound 3, intrinsic clearance in microsomes: < 7 mL.min-1.g-1
Compound 3 ended at the assay's limit; the forecaster's own chance of this, stated with the estimate: 65%; the middle value lies beyond the limit too.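

Among the compounds shown here, no step among compound 1, compound 2 and compound 3 can be read in this assay, because all three stand at a limit: the limit of < 7 mL.min-1.g-1 in this assay, at which 3 of the 3 values shown sit. From the compounds shown here alone, whether 4-aminobutyl and 1-(aminomethyl)-1-methylethyl differ at all on this read-out stays open.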